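Swapping the indolyl group for 3-methylphenyl

A few compounds are considered here, and "the series" means these few. Any claim that something is new, unique, unknown or untested is made for them only; others in the source may bear on it.

In a functional assay on HeLa cells (Homo sapiens) for inhibition, read by CCK-8 assay, with a stated time of 48 h (on this read-out higher numbers stand for weaker inhibition and lower numbers for stronger inhibition), compound 1 (`COc1cc(-c2ccnc3cc(-c4ccccc4)nn23)cc(OC)c1OC`) gives 458 nM. Compound 2 (`COc1cc(-c2ccnc3cc(-c4cn(C)c5ccccc45)nn23)cc(OC)c1OC`) gives 399 nM, which stands level with compound 1 within the scatter. Compound 3 (`COc1cc(-c2ccnc3cc(-c4cccc(C)c4)nn23)cc(OC)c1OC`) carries 3-methylphenyl in place of 1-methyl-1H-indol-3-yl on an aromatic carbon. Among the measured compounds shown here, the one measured step that bears on this change, a 1.1-fold lower number from compound 1 to compound 2 (0.06 log units; within the scatter), exchanged phenyl for the same indolyl group and stayed within the scatter. No step beyond the scatter is therefore expected in this assay, and the expected step is a 1.1-fold higher number from compound 2 to compound 3 (0.02 log units; within the scatter). For compound 3 the estimate is 420 nM, with an expected range of 150 nM to 1200 nM.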

Compound 3, half-maximal inhibitory concentration: 4230 nM
Compound 3: middle estimate off by 10-fold (1.00 log units), on the low side, and the stated range ends below it.
By their numbers in this assay, from the lowest: compounds 2 and 1 (each within the scatter of the next); then compound 3.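

In this assay this position proves far less forgiving than the earlier pair suggested: replacing the indolyl group with 3-methylphenyl gives an 11-fold higher number from compound 2 to compound 3 (1.03 log units; beyond the scatter), and adding one methyl to the phenyl group gives a 9.2-fold higher number from compound 1 to compound 3 (0.97 log units; beyond the scatter). Phenyl and 1-methyl-1H-indol-3-yl stand level, so a small methyl addition matters here where the exchange of those two groups did not. No evidence here accounts for this loss.

The compounds shown leave open whether the loss is specific to methyl or would also follow from a fluorine, a methoxy or an amine at the same place on the phenyl ring.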